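A few compounds are considered here, and "the series" means these few. Any claim that something is new, unique, unknown or untested is made for them only; others in the source may bear on it.

Measured so far in an assay on membranes from HeLa cells for displacement of a labelled ligand from adenosine receptor A3 (Homo sapiens), read by scintillation counting, with a stated time of 180 min, tested at 1 uM; a higher number here means more inhibition at the concentration tested (going by the name of the read-out), a lower number less inhibition:
Compound 1 `CC1=C(C(=O)CC(C)C)C(c2ccco2)NC(=O)N1` gives 31%.
Compound 2 `CC1=C(C(=O)CC(C)C)C(c2ccoc2)NC(=O)N1` gives 18%.
Compound 3 `CC1=C(c2ncc(C)o2)C(c2ccco2)NC(=O)N1` gives 4%.

Compound 1 stands highest of the three numbers, with compound 2 nearest and compound 3 furthest. Compound 4 `CC1=C(C(=O)OCC2CC2)C(c2ccco2)NC(=O)N1` differs from it in one place: cyclopropylmethoxy in place of isobutyl on a carbonyl carbon. Going by the values given here, no measured step exchanges a group on that carbonyl carbon, so the bearing of the known steps is indirect. Both steps away from compound 1 lowered inhibition: a number 13 percentage points lower from compound 1 to compound 2 (beyond the scatter) and a number 27 percentage points lower from compound 1 to compound 3 (beyond the scatter), the second removing the whole isobutylcarbonyl. Because a number 27 percentage points lower from compound 1 to compound 3 (beyond the scatter), a change at the same carbonyl is expected to cost some inhibition, though less, since the carbonyl itself stays. Compound 4 is therefore estimated at 22%, between 8% and 40%. This expected step is a number 9 percentage points lower from compound 1 to compound 4 (within the scatter).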

Compound 4, a percentage reported as inhibition, at one concentration (the size of the read-out at that concentration, not a potency): 1%
Compound 4: middle estimate off by 21 percentage points, on the high side, outside the stated range (below it).
By their numbers in this assay, from the lowest: compounds 4 and 3 (each within the scatter of the next); then compound 2; then compound 1.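

In this assay, replacing isobutyl with cyclopropylmethoxy on the carbonyl carbon gives a number 30 percentage points lower from compound 1 to compound 4 (beyond the scatter). Keeping the carbonyl therefore does not preserve the inhibition seen with compound 1, so the group attached to that carbon matters in its own right. No measurement available here explains this loss.

The compounds shown leave open whether the oxygen or the three-membered ring accounts for the change. An isobutoxy or a cyclopropylmethyl group on the same carbonyl carbon would separate these two parts.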